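The source may report more compounds than this note shows. Statements on the series, on what has been measured and on what is new or still open speak of the compounds shown alone.

Among the measured compounds shown here, compound 1 `CC(C)(C)n1ncc(OCc2nnc(-c3ccc(Cl)cc3Cl)s2)c(Cl)c1=O` is the one member of this small set for which a number, rather than a limit, was obtained. In a functional assay on the whole organism for inhibition, with Mythimna separata as the target, with a stated time of 5 days (a higher number here means that more compound is needed for the effect, a lower number that less compound is needed), compound 1 gives 62.2 ug/mL. Two related compounds reached only the limit of the assay. Compound 2 `COc1c(F)c(F)cc(-c2nnc(COc3cnn(C(C)(C)C)c(=O)c3Cl)o2)c1F` gives in this assay the limit > 300 ug/mL, which is not a number. Compound 3 `CC(C)(C)n1ncc(OCc2nnc(-c3cc(F)c(Cl)c([N+](=O)[O-])c3Cl)o2)c(Cl)c1=O` likewise gives in this assay the limit > 300 ug/mL. Two of the three values shown thus sit at the limit of > 300 ug/mL in this assay, at which 2 of the 3 values shown sit, and compound 1 stands alone with a measured number. For the measured compounds named here, no pair of these measured compounds differs in a single place, so there is no measured step to lean on.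

Compound 4 `Cc1cccc(-c2nnc(COc3cnn(C(C)(C)C)c(=O)c3Cl)s2)c1` has not yet been measured. It differs from compound 1 by one change: 3-methylphenyl in place of 2,4-dichlorophenyl on an aromatic carbon. Both compounds keep the shared core and the five-membered ring that carries the aryl group. Going by the values given here, with no measured step of this kind, the direction remains open; the change is expected either to stay within the scatter or to cost some potency. The step that this estimate means is a 1.6-fold higher number from compound 1 to compound 4 (0.21 log units; within the scatter), an expectation rather than a measurement. Compound 4 is therefore expected to give in this assay about 100 ug/mL, with a range from 30 ug/mL to 300 ug/mL.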

Compound 4, half-maximal effective concentration: > 300 ug/mL
Compound 4 was reported as a limit; the forecaster's own chance of this, stated with the estimate: 35%; middle value at least 3.0-fold (0.47 log units) away from the limit.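

Among the compounds shown here, this is the first measured step at this position. In this assay, placing 3-methylphenyl instead of 2,4-dichlorophenyl on the aromatic carbon of the five-membered ring, with the rest of the molecule unchanged, gives an at least 4.8-fold higher number from compound 1 to compound 4 (0.68 log units; beyond the scatter), a step beyond the usual scatter and a clear loss of potency for this pair, so these two aryl groups are not interchangeable here. The printed step is only a minimum and its true size remains unknown, because compound 4 reached a limit of the assay rather than giving a number: the limit of > 300 ug/mL in this assay, at which 3 of the 4 values shown sit.

This single pair cannot show whether the difference lies with losing the two chlorine atoms, with gaining the methyl group, or with both, since the change alters all of these at once. As far as these compounds go, how an unsubstituted phenyl or a pyridyl group would behave at this same place remains open, and either could help to separate these possibilities.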